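The source may hold more compounds than are shown below. What is called first, only, known or untested is meant among the compounds shown, and "the series" means these compounds.

Three compounds have been measured in an assay on membranes from CHO cells for displacement of a labelled ligand from adenosine receptor A1 (Homo sapiens), read by scintillation counting, with a stated time of 60 min, tested at 1 uM; on this read-out higher numbers stand for more inhibition at the one concentration tested (going by the name of the read-out) and lower numbers for less inhibition:

Compound 1 `CCN(CC)C(=O)C1=C(C)NC(=O)NC1c1cccs1`: 13%
Compound 2 `CCC(C)OC(=O)C1=C(C)NC(=O)NC1c1cccs1`: 5%
Compound 3 `CC1=C(C(=O)OC2CCCC2)C(c2cccs2)NC(=O)N1`: 9%

All three share the same core and differ only in the group on the carbonyl carbon. Compound 3 has the second highest of the three numbers, but the steps leading to it, a number 4 percentage points lower from compound 1 to compound 3 (within the scatter) and a number 4 percentage points higher from compound 2 to compound 3 (within the scatter), both sit within the usual scatter, so the three values cannot be told apart with confidence.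

Compound 4 `CC1=C(C(=O)OCC2CC2)C(c2cccs2)NC(=O)N1` has not yet been measured. It differs from compound 3 in one place: cyclopropylmethyl in place of cyclopentyl on an oxygen next to a carbonyl group. Among the measured compounds shown here, one measured step bears directly on a change of this kind, a swap of the group on the oxygen next to a carbonyl group: a number 4 percentage points higher from compound 2 to compound 3 (within the scatter), which lies within the scatter. The other two steps, a number 8 percentage points lower from compound 1 to compound 2 (within the scatter) and a number 4 percentage points lower from compound 1 to compound 3 (within the scatter), replace diethylamino and also lie within the scatter. Nothing seen so far therefore points to a step beyond the scatter in this assay. The expected step is no change at the digits printed from compound 3 to compound 4 (within the scatter). Compound 4 is estimated at 9%, with a range from 0% to 20%.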

Compound 4, a percentage reported as inhibition, at one concentration (the size of the read-out at that concentration, not a potency): 23%
The estimate for compound 4 lay 14 percentage points below the measured number; the whole stated range lies below it.
By their numbers in this assay, from the lowest: compounds 2, 3, 1 and 4 (each within the scatter of the next, the first and the last beyond it).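

In this assay, among the compounds shown here, the group on the oxygen next to a carbonyl group now shows an effect that the earlier compounds could not show: putting cyclopropylmethyl there in place of cyclopentyl gives a number 14 percentage points higher from compound 3 to compound 4 (beyond the scatter) and is the first change here to clear the scatter, while putting it in place of sec-butyl gives a number 18 percentage points higher from compound 2 to compound 4 (beyond the scatter) as a second such step. Both steps remain modest, and the comparison with the diethylamino group on the carbonyl carbon, a number 10 percentage points higher from compound 1 to compound 4 (within the scatter) for cyclopropylmethoxy, cannot separate those two groups. No measurement at hand explains the rise seen with cyclopropylmethyl.

The compounds shown leave open whether the rise goes with the three-membered ring itself or with the carbon that carries it, which a cyclobutylmethyl group or a plain butyl chain on the same oxygen could test. They also leave open how potent any of these compounds is, since each number comes from a single concentration.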